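The source may hold more compounds than are shown below. What is called first, only, known or untested is meant among the compounds shown, and "the series" means these compounds.

Measured compounds:
compound 1 `CC(=O)Oc1ccccc1C(=O)O[C@H]1CO[C@H]2[C@@H]1OC[C@H]2OC(=O)c1cccc(O)c1` — 0.015 h
compound 2 `CC(=O)Oc1ccccc1C(=O)O[C@H]1CO[C@H]2[C@@H]1OC[C@H]2OC(=O)c1ccc(C)cc1` — 0.0362 h
compound 3 `CC(=O)Oc1ccccc1C(=O)O[C@H]1CO[C@H]2[C@@H]1OC[C@H]2OC(=O)c1ccccc1OC(=O)c1ccccc1` — 0.0722 h

All three share one core and differ only in the ester group on one side. In an ADME assay on a cell-free system (plasma, Homo sapiens) for metabolic stability, with Plasma (Rattus norvegicus) as the target, read by HPLC, at pH 7.4 (a lower number here means that the compound disappears faster, a higher number that the compound lasts longer), compound 2 stands second highest of the three: its value and that of compound 3 lie within the scatter of each other, while a 2.4-fold higher number from compound 1 to compound 2 (0.38 log units; beyond the scatter), a modest but real gain. Compound 4 `CC(=O)Oc1ccccc1C(=O)O[C@H]1CO[C@H]2[C@@H]1OC[C@H]2OC(=O)CO[N+](=O)[O-]` changes the same position: (nitrooxy)methyl in place of 4-methylphenyl on a carbonyl carbon. Within the data shown here, the only measured step swaps one substituent on an aromatic ring for another, so nothing measured speaks to removing the ring altogether, and no direction beyond the scatter is expected. Compound 4 is therefore estimated at 0.03 h, with a range from 0.01 h to 0.1 h. The expected step is a 1.2-fold lower number from compound 2 to compound 4 (0.08 log units; within the scatter), within the scatter.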

Compound 4, half-life: 0.015 h
Compound 4: the middle estimate sits 2.0-fold (0.30 log units) above what was measured, within the range that was stated.
By their numbers in this assay, from the lowest: compounds 1 and 4 (each within the scatter of the next); then compounds 2 and 3 (each within the scatter of the next).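

In this assay, a step away from the aromatic ring gives a 2.4-fold lower number from compound 2 to compound 4 (0.38 log units; beyond the scatter), so this position responds to an open (nitrooxy)methyl chain, which the earlier ring-for-ring comparison could not show. With no change at the digits printed from compound 1 to compound 4 (within the scatter), a compound without the ring and one with 3-hydroxyphenyl land together, so the ring's absence is not required for so short a half-life. Nothing available explains the drop. The compounds shown leave open whether the ring's loss or the nitrooxy group drives this step. A plain ethyl chain on the same carbonyl carbon would help separate the two.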